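The source may report more compounds than this note shows. Statements on the series, on what has been measured and on what is new or still open speak of the compounds shown alone.

Compound 1 `O=c1[nH]ccn1CCOc1nn(-c2ccccc2F)c2ccc(F)cc12`: 0.4 h
Compound 2 `CC(Oc1nn(-c2ccccc2F)c2ccc(F)cc12)C(=O)N1CCOCC1`: 2 h

In an ADME assay on the whole organism (strain Sprague-Dawley) for metabolic stability, with Rattus norvegicus as the target, read by LC-MS (a lower number here means that the compound disappears faster, a higher number that the compound lasts longer), compound 1 gives 0.4 h, the lower of the two numbers. Compound 2 reaches 2 h, a gap beyond the usual scatter. These two compounds differ in more than one place, so their gap cannot be tied to any single structural change.

Compound 3 `O=C1NCCN1CCOc1nn(-c2ccccc2F)c2ccc(F)cc12` keeps the core of compound 1 and changes one group: a group of 6 heavy atoms (3 carbon, 2 nitrogen, 1 oxygen; one five-membered non-aromatic ring with 2 hetero atoms) in place of a group of 6 heavy atoms (3 carbon, 2 nitrogen, 1 oxygen; one five-membered aromatic ring with 2 hetero atoms), on a saturated chain carbon, two bonds along the chain from an oxygen on an aromatic ring. The new group is 2-oxoimidazolidin-1-yl, and its ring is non-aromatic where the old one was aromatic. Going by the values given here, no measured pair shows what this swap does to this assay, so the expectation starts from compound 1 at 0.4 h, its closest measured relative. A small rise, staying within the scatter, is expected: a 1.3-fold higher number from compound 1 to compound 3 (0.10 log units; within the scatter). For compound 3 the estimated half-life is 0.5 h, with an expected range of 0.2 h to 1.3 h.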

Compound 3, half-life: 0.4 h
Compound 3: the middle estimate sits 1.3-fold (0.10 log units) above what was measured; low and high end bracket the measured number.
By their numbers in this assay, from the lowest: compounds 1 and 3 (each within the scatter of the next); then compound 2.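

In this assay, replacing the aromatic five-membered ring of compound 1 with the non-aromatic 2-oxoimidazolidin-1-yl ring of compound 3 gives no change at the digits printed from compound 1 to compound 3 (within the scatter). Going by these compounds alone, this is the first single-place comparison, and it shows that, on this core and at this spot on the chain, losing the ring's aromatic character leaves the half-life unmoved. The two groups have the same heavy-atom count, so this pair tests a change in ring type and not in group size. Nothing available explains this result.

This one pair cannot show whether the half-life at this position would respond to a different kind of group, such as an amine or a carboxylic acid. It also leaves open what a longer chain between the ring and the oxygen would do.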